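Methyl-for-hydrogen extension on two cores: lipophilicity notes

A few compounds are considered here, and "the series" means these few. Any claim that something is new, unique, unknown or untested is made for them only; others in the source may bear on it.

Two pairs share one kind of change. Compound 2 `COc1ccccc1-c1nc(N)nc(N)n1` carries a methoxy group; compound 1 `CCOc1ccccc1-c1nc(N)nc(N)n1` carries an ethoxy group in its place. In a physicochemical assay for lipophilicity (on this read-out higher numbers stand for higher lipophilicity and lower numbers for lower lipophilicity), compound 2 gives 0.58, and compound 1 gives 1.03. The change is methyl in place of hydrogen on a saturated chain carbon bound to an oxygen on an aromatic ring, and it made a step of a number 0.45 log units higher from compound 2 to compound 1 (beyond the scatter).

Compound 3 `CCN(CC)c1c(C)n(-c2ccccc2)c(=O)n(C)c1=O` rests on a different core; the difference between the two cores is not broken down here. In this assay compound 3 gives 2.19, the highest of the three measured numbers, with compound 1 below it and compound 2 further below. Compound 4 `CCN(CC)c1c(C)n(-c2ccccc2)c(=O)n(CC)c1=O` has not been measured in this assay. It differs from compound 3 by methyl in place of hydrogen on a saturated chain carbon bound to an aromatic nitrogen. This is the same kind of change as that from compound 2 to compound 1, not the same: the carbon is bound to an aromatic nitrogen rather than to an oxygen on an aromatic ring. For compound 4 the expected step is a number 0.45 log units higher from compound 3 to compound 4 (beyond the scatter). Among the measured compounds shown here, that expectation rests on a number 0.45 log units higher from compound 2 to compound 1 (beyond the scatter), the one earlier example of this kind of change, with only the place differing. Compound 4 is therefore estimated at 2.64 in this assay, within a range from 2.3 to 3.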

Compound 4, partition coefficient: 2.78
Compound 4: the middle estimate sits 0.14 log units below what was measured; low and high end bracket the measured number.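

In this assay the change on a saturated chain carbon bound to an aromatic nitrogen gives a number 0.59 log units higher from compound 3 to compound 4 (beyond the scatter) on one core, and the same kind of change on a saturated chain carbon bound to an oxygen on an aromatic ring gives a number 0.45 log units higher from compound 2 to compound 1 (beyond the scatter) on the other, so the two steps run in the same direction. This shows that the direction of methyl in place of hydrogen carried over in these two pairs, but with one pair per core it does not establish a general rule, and since core and place differ together, neither can be judged apart from the other. Nothing at hand gives a reason for the size of either step.

The compounds shown leave open whether a longer chain such as propyl at this place would extend the same direction in this assay on either core. Also open, from the compounds shown here alone, is how an amine or a carboxylic acid at the end of that chain would read.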